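Benzyl for methoxy on an ethyl ester

A few compounds are considered here, and "the series" means these few. Any claim that something is new, unique, unknown or untested is made for them only; others in the source may bear on it.

Measured in a functional assay on HCT-116 cells (Homo sapiens) for cytotoxicity, read by MTT assay, with a stated time of 72 h; a higher number here means that more compound is tolerated, a lower number that less compound is tolerated:
- compound 1 `COc1ccc2c(c1)c(O)c(C(=O)O)c(=O)n2C`: > 10000 nM
- compound 2 `Cn1c(=O)c(C(=O)O)c(O)c2cc(Cc3ccccc3)ccc21`: > 10000 nM
- compound 3 `CCOC(=O)c1c(O)c2cc(OC)ccc2n(C)c1=O`: > 10000 nM

Compound 3 stands only at a limit, > 10000 nM. It shares this position with the other two compounds: the limit of > 10000 nM in this assay, at which 3 of the 3 values shown sit. Compound 4 `CCOC(=O)c1c(O)c2cc(Cc3ccccc3)ccc2n(C)c1=O` carries benzyl in place of methoxy on an aromatic carbon. The same exchange appears in a step that the two limits leave unreadable from compound 1 to compound 2, while ethyl in place of hydrogen appears in a step that the two limits leave unreadable from compound 1 to compound 3. Neither size can be read, so neither points to a direction. No change beyond the scatter is therefore expected in this assay, and the estimate is a step that the limit leaves unreadable from compound 3 to compound 4. For compound 4 the expected value is 12000 nM, with an estimated range of 4000 nM to 30000 nM.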

Compound 4, half-maximal cytotoxic concentration: > 10000 nM
Compound 4 ended at the assay's limit (the forecaster's own chance of this, stated with the estimate: 70%); the middle value is on the limit's open side.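

In this assay compound 4 gives > 10000 nM, which is a limit. Going by these compounds alone, no step from compound 3 or compound 2 to compound 4 can be read. The compounds shown leave open what either exchange does to cytotoxicity, and where any of the four has its actual value: the limit of > 10000 nM in this assay, at which 4 of the 4 values shown sit.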